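Removing One Methyl From an Aryl Imine Series

The source may hold more compounds than are shown below. What is called first, only, known or untested is meant among the compounds shown, and "the series" means these compounds.

Of the compounds shown here, two built on a shared core have been measured in a functional assay on the whole organism (strain Wistar) for inhibition, with Rattus norvegicus as the target, read by paw edema, with stated times of 30 min and 120 min, at a dose of 10 mg/kg by the oral route; on this read-out lower numbers stand for less inhibition and higher numbers for more inhibition at the one dose given (going by the name of the read-out). Compound 1 `O=C1N/C(=N/c2ccc(F)cc2)S/C1=C\c1ccccn1` carries a fluorine on its aryl ring, and in this assay compound 1 gives 34.7%. Compound 2 `Cc1cccc(C)c1/N=C1/NC(=O)/C(=C/c2ccccn2)S1` carries two methyl groups instead, and in this assay compound 2 gives 39.7%. The gap between these two numbers lies within the usual scatter of repeated measurements, so the two compounds cannot be told apart on this read-out.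

Compound 3 `Cc1ccccc1/N=C1/NC(=O)/C(=C/c2ccccn2)S1` has not yet been measured. It differs from compound 2 in one place: hydrogen in place of methyl on an aromatic carbon. The change is small, one carbon fewer on the aryl ring, and the two measured compounds show that swapping the whole substitution pattern on that ring left the read-out essentially unchanged. Compound 3 is therefore expected to produce a step of a number 1.7 percentage points lower from compound 2 to compound 3 (within the scatter) that stays within the scatter, with no direction favoured. The estimate for compound 3 in this assay is 38%, with a likely range from 25% to 51%.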

Compound 3, a percentage reported as inhibition, in the whole organism at one dose (the size of the read-out at that dose, not a potency): 30.4%
For compound 3 the middle estimate is 7.6 percentage points above the measured one; low and high end bracket the measured number.
By their numbers in this assay, from the lowest: compounds 3, 1 and 2 (each within the scatter of the next).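

In this assay, hydrogen in place of methyl on an aromatic carbon, ortho to a large group and meta to a methyl group, gives a number 9.3 percentage points lower from compound 2 to compound 3 (within the scatter), so the first change made at this one position cannot be told apart from repeat measurement. The comparison with the fluorinated compound gives the same picture: 2-methylphenyl in place of 4-fluorophenyl on a double-bonded nitrogen gives a number 4.3 percentage points lower from compound 1 to compound 3 (within the scatter), so this exchange on the same aryl ring also leaves this assay without a resolved difference. No independent evidence bears on these results, and they offer no account of what lies behind either step.

The compounds shown leave open whether any group at this position can move the read-out beyond the scatter, for instance a methoxy group, a chlorine atom, an amine or a longer chain such as ethyl in place of the methyl. They also leave open how a plain phenyl ring, carrying only hydrogen where these compounds carry methyl or fluorine, would stand in this assay against compound 3 on the shared core.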